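Allyl in Place of Ethyl: Compound 3 Awaits Measurement

The source may report more compounds than this note shows. Statements on the series, on what has been measured and on what is new or still open speak of the compounds shown alone.

Of the compounds shown here, two have numbers so far. Compound 1 `CCOc1ccc(NC(=O)c2c(N)n[nH]c2NC)cc1` gives 7900 nM in a functional assay on CCRF-CEM cells (Homo sapiens) for cytotoxicity, read by resazurin assay, with a stated time of 48 h; a lower number here means a stronger inhibitor, a higher number a weaker inhibitor. Compound 2 `CCN/C(SC)=C(/C#N)C(=O)Nc1ccc(OCC)cc1` gives 9890 nM in this assay; this is the higher of the two numbers, but its nearest neighbour, compound 1, sits within the scatter of it, so the pair cannot be put in order. Compound 3 `C=CCN/C(SC)=C(/C#N)C(=O)Nc1ccc(OCC)cc1` has not yet been measured in this assay. It differs from compound 2 by vinyl in place of methyl on a saturated chain carbon bound to an amine nitrogen, which read one bond further out is ethyl to allyl, ethylamino to allylamino. Among the measured compounds shown here, no step between measured compounds bears on this change, since compounds 1 and 2 differ in several places at once. The account therefore expects the step from compound 2 to compound 3 to stay within the scatter, without a clear direction, a 1.1-fold lower number from compound 2 to compound 3 (0.04 log units; within the scatter). Compound 3 is accordingly estimated at 9000 nM, within a range from 4000 nM to 22000 nM.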

Compound 3, half-maximal inhibitory concentration: 18500 nM
Compound 3: middle estimate off by 2.1-fold (0.31 log units), on the low side, within the range that was stated.
By their numbers in this assay, from the lowest: compounds 1, 2 and 3 (each within the scatter of the next, the first and the last beyond it).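

Among the compounds shown here, this is the first step that can be read at this position: in this assay, vinyl in place of methyl on a saturated chain carbon bound to an amine nitrogen gives a 1.9-fold higher number from compound 2 to compound 3 (0.27 log units; within the scatter). Ethylamino to allylamino, a change that adds one carbon and a double bond outside aromatic rings, therefore leaves the two numbers impossible to put in order, although the step lies close to the limit of the scatter. No measurement at hand speaks to what lies behind this step.

On these data alone, whether a propyl group, a benzyl group or a longer chain on this amine nitrogen would carry the number clearly beyond the scatter remains open. Also open, as far as these compounds go, is whether allylamino on the core of compound 1 would read the same way.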